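The source may hold more compounds than are shown below. What is called first, only, known or untested is meant among the compounds shown, and "the series" means these compounds.

Compound 1 `COc1cc(-c2nn(-c3cccc(NC(=O)Nc4cc(C(F)(F)F)cc(C(F)(F)F)c4)c3)cc2-c2ccncc2)ccc1Cl` gives 1090 nM in a functional assay on NCI-H23 cells (Homo sapiens) for inhibition, read by sulforhodamine B assay, with a stated time of 48 h; on this read-out lower numbers stand for stronger inhibition of growth and higher numbers for weaker inhibition of growth.
Compound 2 `COc1cc(-c2nn(-c3cccc(NC(=O)Nc4ccc(Cl)c(Cl)c4)c3)cc2-c2ccncc2)ccc1Cl` gives 1410 nM in this assay.
Compound 3 `O=C(Nc1cccc(-n2cc(-c3ccncc3)c(-c3ccc(Cl)c(O)c3)n2)c1)Nc1ccc(Cl)c(Cl)c1` gives 1220 nM in this assay.

Compound 3 stands second highest of the three numbers in this assay, but its nearest neighbour, compound 1, and its furthest, compound 2, both lie within the scatter of it, so the three compounds are not separated. Among the measured compounds shown here, the one step that is fully charted, a 1.2-fold lower number from compound 2 to compound 3 (0.06 log units; within the scatter), concerns the methyl on the oxygen and does not touch the urea aryl.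

Compound 4 `O=C(Nc1cccc(-n2cc(-c3ccncc3)c(-c3ccc(Cl)c(O)c3)n2)c1)Nc1ccc(Cl)c(C(F)(F)F)c1` differs from compound 3 in that aryl: trifluoromethyl in place of chloro on an aromatic carbon. For the measured compounds named here, no measured step follows this exact change; compound 1 carries two trifluoromethyl groups where compound 2 carries two chloro groups, but the two also differ elsewhere, and their values in this assay stand within the scatter of each other. Compound 4 is therefore expected to show no shift beyond the scatter, a 1.1-fold lower number from compound 3 to compound 4 (0.04 log units; within the scatter). The estimate for compound 4 in this assay is 1100 nM, with a range from 500 nM to 2500 nM.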

Compound 4, concentration for 50% growth inhibition: 951 nM
Estimate against measurement, compound 4: 1.2-fold (0.06 log units) above; low and high end bracket the measured number.
By their numbers in this assay, from the lowest: compounds 4, 1, 3 and 2 (each within the scatter of the next).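

On the aromatic carbon ortho to a chloro group and meta to a large group, trifluoromethyl in place of chloro gives a 1.3-fold lower number from compound 3 to compound 4 (0.11 log units; within the scatter) in this assay. Unlike the comparison of compound 1 with compound 2, this step reads the change alone, with the rest of the structure held constant. It shows that a group of four heavy atoms can replace one of a single heavy atom here without a shift beyond the scatter, and no measured property bears on this result.

Because the step lies within the scatter, the compounds shown do not establish that this position has any effect on growth inhibition. As far as these compounds go, what an amine or a carboxylic acid would do on this carbon stays open, as does whether the same exchange gives a similar step alongside a methoxy group in place of the hydroxy group.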